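One more methoxy on compound 2

The source may hold more compounds than are shown below. What is called first, only, known or untested is meant among the compounds shown, and "the series" means these compounds.

In a functional assay on MCF7 cells (Homo sapiens) for inhibition, read by MTT assay, with a stated time of 48 h (on this read-out higher numbers stand for weaker inhibition of growth and lower numbers for stronger inhibition of growth), compound 1 `Cn1cc(C2CC(c3ccccc3)=NN2C(=O)c2cccnc2)c2cc(Br)ccc21` gives 1520 nM and compound 2 `COc1ccc(C2=NN(C(=O)c3cccnc3)C(c3cn(C)c4ccc(Br)cc34)C2)cc1OC` gives 1170 nM as its value, so these two numbers lie within the usual scatter of each other. Compound 3 `COc1cc(C2=NN(C(=O)c3cccnc3)C(c3cn(C)c4ccc(Br)cc34)C2)cc(OC)c1OC` differs from compound 2 by methoxy in place of hydrogen on an aromatic carbon and this turns 3,4-dimethoxyphenyl into 3,4,5-trimethoxyphenyl. For the measured compounds named here, only one measured step bears on this change. It is a 1.3-fold lower number from compound 1 to compound 2 (0.11 log units; within the scatter) and it came from putting 3,4-dimethoxyphenyl in place of phenyl. With that single small step as the guide, no shift beyond the scatter is expected in this assay in either direction, though one step is thin evidence. The estimated change is a 1.2-fold lower number from compound 2 to compound 3 (0.07 log units; within the scatter) at the middle of the range. Compound 3 is expected near 1000 nM with an estimated range from 400 nM to 2500 nM as its likely span.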

Compound 3, concentration for 50% growth inhibition: > 10000 nM
Compound 3 ended at the assay's limit; the forecaster's own chance of this, stated with the estimate: 3%; middle value at least 10-fold (1.00 log units) from the limit.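

In this assay compound 3 gives > 10000 nM, which is a limit of the assay and not a number: the limit of > 10000 nM in this assay, at which 1 of the 3 values shown sits.

The added methoxy, ortho to a methoxy group, gives an at least 8.5-fold higher number from compound 2 to compound 3 (0.93 log units; beyond the scatter), whereas the earlier move from phenyl to 3,4-dimethoxyphenyl gave only a 1.3-fold lower number from compound 1 to compound 2 (0.11 log units; within the scatter). Set against plain phenyl, the full change gives an at least 6.5-fold higher number from compound 1 to compound 3 (0.81 log units; beyond the scatter), so among these three compounds the ring with two methoxy groups leaves growth inhibition within the scatter of phenyl, while a third carries it beyond the scatter.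

On these data alone, whether a hydroxyl or an amine on this same aromatic carbon would keep the growth inhibition of compound 2 stays open. Also open, as far as these compounds go, is whether a methoxy here would have the same effect without the other two methoxy groups on the ring.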